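Acylhydrazone aryl variation in the shared core series

The source may report more compounds than this note shows. Statements on the series, on what has been measured and on what is new or still open speak of the compounds shown alone.

Of the compounds shown here, three of the shared core have been measured in a functional assay on U-87MG ATCC cells (Homo sapiens) for cytotoxicity, read by MTT assay, with a stated time of 72 h; on this read-out lower numbers stand for stronger inhibition and higher numbers for weaker inhibition. Compound 1 `CN(C)CCn1cnnc1-c1cc(Oc2ccc(NC(=O)N/N=C/c3cc(C(C)(C)C)cc(C(C)(C)C)c3O)cc2F)ccn1` gives 520 nM. Compound 3 `CN(C)CCn1cnnc1-c1cc(Oc2ccc(NC(=O)N/N=C/c3ccc(F)cc3)cc2F)ccn1`, carrying a 4-fluorophenyl on the carbon with a double bond to nitrogen, gives 2310 nM; this is the highest of the two numbers obtained, compound 1 sitting lower by a step beyond the scatter. Compound 2 `Cn1ncnc1-c1cc(Oc2ccc(NC(=O)N/N=C/c3ccccc3)cc2F)ccn1` gives only a limit in this assay, > 100000 nM, and no number; the evidence on that is the limit of > 100000 nM in this assay, at which 1 of the 3 values shown sits.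

Compound 4 `CN(C)CCn1cnnc1-c1cc(Oc2ccc(NC(=O)N/N=C/c3ccc(O)c(F)c3)cc2F)ccn1` is not yet measured. It differs from compound 3 in one place (3-fluoro-4-hydroxyphenyl in place of 4-fluorophenyl on a carbon with a double bond to nitrogen). Within the data shown here, no measured pair describes this change, so its size is open. A counted hydrogen-bond donor and acceptor enter on the aryl group; compound 1, which also carries such a group on its aryl ring, gives 520 nM, but its aryl differs in other places as well. The step from compound 3 to compound 4 is expected to be modest, toward a lower number or none beyond the scatter, a 1.5-fold lower number from compound 3 to compound 4 (0.19 log units; within the scatter). Compound 4 is estimated at 1500 nM, between 500 nM and 5000 nM.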

Compound 4, half-maximal inhibitory concentration: > 100000 nM
Compound 4: no number, only a limit (the forecaster's own chance of this, stated with the estimate: 5%); middle value at least 66-fold (1.82 log units) from the limit.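

On the carbon with a double bond to nitrogen, a single change of aryl group is now seen to have a large effect in this assay: 3-fluoro-4-hydroxyphenyl in place of 4-fluorophenyl gives an at least 43-fold higher number from compound 3 to compound 4 (1.63 log units; beyond the scatter). Among these compounds, this is the first step between compounds that differ in one place, and it shows that adding a hydroxyl to this fluorinated aryl group can carry the read-out out of the measurable range. The value of compound 4 is a limit and not a number, so the step has no upper end, and compound 2 has the same limit: the limit of > 100000 nM in this assay, at which 2 of the 4 values shown sit.

The compounds shown do not separate the effect of the hydroxyl from that of the changed fluorine placement. From the compounds shown here alone, whether a methoxy group or an amine on the aryl group would keep a measurable number also remains open.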